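Swapping the sulfonyl aryl group on a shared core

This account rests on a few compounds, and the source may have more. Where it says the series, first, only, none or still open, it means among the compounds named here.

Measured compounds:
compound 1, `CC1CCN(c2c(S(=O)(=O)c3ccc(F)c(Cl)c3)cnc3cc(F)ccc23)CC1`: 94%
compound 2, `CC1CCN(c2c(S(=O)(=O)c3ccc(Cl)c(Cl)c3)cnc3ccc(Cl)cc23)CC1`: 86%
compound 3, `CC1CCN(c2c(S(=O)(=O)c3ccc(F)c(Cl)c3)cnc3cc(Cl)ccc23)CC1`: 94%

Three compounds share one core and were tested in an assay on isolated protein for displacement of a labelled ligand from metabotropic glutamate receptor 5 (Homo sapiens), with a stated time of 60 min, tested at 1 uM; on this read-out higher numbers stand for more inhibition at the one concentration tested (going by the name of the read-out) and lower numbers for less inhibition. Going by the values given here, compound 1 gives 94%, and compound 3 gives 94%; the only measured single-point step, no change at the digits printed from compound 1 to compound 3 (within the scatter), shows that a chloro in place of a fluoro on an aromatic carbon of the core leaves the read-out unchanged. Two places differ between compound 1 and compound 2; in this assay compound 2 gives 86%, a number within the scatter of the other two. Among the compounds with values here, compound 1 therefore stands level with compound 3 and within the scatter of compound 2; no compound can be said to have the highest number.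

Compound 4, `Cc1ccc(S(=O)(=O)c2cnc3cc(F)ccc3c2N2CCC(C)CC2)cc1`, is not yet measured. It differs from compound 1 by 4-methylphenyl in place of 3-chloro-4-fluorophenyl on a sulfonyl sulfur. Within the data shown here, no measured step touches this sulfonyl aryl group: the step from compound 1 to compound 3 concerns the core halogen only, and compound 2 changes two places at once. The expectation for compound 4 thus rests on the high and flat numbers of the three measured compounds, and a step of a number 14 percentage points lower from compound 1 to compound 4 (beyond the scatter) is expected, with a wider range than the measured scatter. Compound 4 is estimated at 80%, between 50% and 96%.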

Compound 4, a percentage reported as inhibition, at one concentration (the size of the read-out at that concentration, not a potency): 88%
Compound 4: the middle estimate sits 8 percentage points below what was measured; the measured number falls inside the stated range.
By their numbers in this assay, from the lowest: compounds 2, 4, 1 and 3 (each within the scatter of the next).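

The sulfonyl aryl group now has a step of its own: in this assay there is a number 6 percentage points lower from compound 1 to compound 4 (within the scatter) for 4-methylphenyl in place of 3-chloro-4-fluorophenyl on a sulfonyl sulfur. In this one pair, then, the aryl group gives up both its halogens for a methyl without the read-out leaving the scatter, so these halogens are not needed for a high number at the one concentration tested. Nothing at hand explains why the read-out holds through this change.

On these data alone, whether the sulfonyl sulfur also accepts something other than a substituted phenyl, such as a plain alkyl chain, or a phenyl carrying an amine or a carboxylic acid, stays open. With all the numbers this high at a single concentration, any differences in potency among these compounds also remain unresolved.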